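The source may report more compounds than this note shows. Statements on the series, on what has been measured and on what is new or still open speak of the compounds shown alone.

Measured compounds in an ADME assay on microsomes from liver (Homo sapiens) for metabolic stability; on this read-out higher numbers stand for a longer-lived compound and lower numbers for a shorter-lived compound:
compound 1 `C[C@@H]1CCC[C@H](N2CCC(c3cc(Cl)ccc3-n3ccnn3)=CC2=O)c2cc(ccn2)-c2c(cnn2C2CCC2)NC1=O`: 0.1 h
compound 2 `C[C@@H]1CCC[C@H](N2CCC(c3cc(Cl)ccc3-n3cc(Cl)nn3)=CC2=O)c2cc(ccn2)-c2c(cnn2C(F)F)NC1=O`: limit, see below
compound 3 `C[C@@H]1CCC[C@H](n2cnc(-c3cc(Cl)ccc3-n3cc(Cl)nn3)cc2=O)c2cc(ccn2)-c2c(cnn2C)NC1=O`: 1.93 h

Compound 2 is reported only as a limit of this assay, > 2 h; it carries the limit of > 2 h in this assay, at which 1 of the 3 values shown sits, and gives no number.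

Among the numbers shown, compound 1 stands lowest; the nearest value, that of compound 3, lies well beyond the scatter of repeat measurement, so the two are clearly set apart. Going by the values given here, compound 3 and compound 2 differ from compound 1 in several places at once, so no single step between the measured compounds can be read off.

Compound 4 `CCn1ncc2c1-c1ccnc(c1)[C@@H](N1CCC(c3cc(Cl)ccc3-n3ccnn3)=CC1=O)CCC[C@@H](C)C(=O)N2` is not yet measured. It differs from compound 1 in one place: ethyl in place of cyclobutyl on an aromatic nitrogen. Among the compounds with values here, with no measured step for this change, the expectation rests only on the spread of the three values. A modest increase in this assay is expected, a 3.0-fold higher number from compound 1 to compound 4 (0.48 log units; beyond the scatter), though it may stay within the scatter. The estimate for compound 4 is 0.3 h, expected to fall between 0.1 h and 1 h.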

Compound 4, half-life: 0.167 h
Estimate against measurement, compound 4: 1.8-fold (0.25 log units) above, within the range that was stated.
By their numbers in this assay, from the lowest: compounds 1 and 4 (each within the scatter of the next); then compound 3. At a limit, above all of these: compound 2.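

In this assay the change at this position, ethyl in place of cyclobutyl on the aromatic nitrogen, gives a 1.7-fold higher number from compound 1 to compound 4 (0.22 log units; within the scatter). Losing the four-membered carbon ring at this nitrogen therefore does not set the two compounds apart on this read-out, and the position has so far shown no measurable response to this one swap between two small carbon groups. Nothing measured here bears on a cause for this result.

Open, going by these compounds, is what a methoxyethyl chain or a hydroxyethyl chain on this nitrogen would do on the core of compound 1. Difluoromethyl and methyl stand at this nitrogen only in compound 2 and compound 3, which also differ from compound 1 elsewhere, so no step to them can be read.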